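A few compounds are considered here, and "the series" means these few. Any claim that something is new, unique, unknown or untested is made for them only; others in the source may bear on it.

Working notes on the series, read in an ADME assay on BHK-21 cells (Mesocricetus auratus) for cytotoxicity, read by MTT assay; a lower number here means that less compound is tolerated, a higher number that more compound is tolerated. Compound 1, `C/C(=N\NC(N)=O)c1ccc2[nH]c(-c3ccccc3)nc2c1`, gives > 100000 nM, which is a limit of the assay and not a number. Compound 2, `C/C(=N\NC(N)=S)c1ccc2[nH]c(-c3ccccc3)nc2c1`, gives 32000 nM, the higher of the two true numbers in the series, and compound 3, `C/C(=N\NC(N)=S)c1ccc2[nH]c(-c3ccc(C(F)(F)F)cc3)nc2c1`, gives 5000 nM.

Compound 4, `C/C(=N\NC(N)=S)c1ccc2[nH]c(C3CCCCC3)nc2c1`, has not yet been measured in this assay. It differs from compound 2 at a single place: cyclohexyl in place of phenyl on an aromatic carbon. In words, this is cyclohexyl in place of phenyl on an aromatic carbon, between two ring nitrogen atoms.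

Two measured steps are available. The step of an at least 3.1-fold lower number from compound 1 to compound 2 (0.49 log units; beyond the scatter) is a change on an amine nitrogen, away from the phenyl group, so it says little here. The step of a 6.4-fold lower number from compound 2 to compound 3 (0.81 log units; beyond the scatter) is closer, as it places trifluoromethyl on that same phenyl group, and it shows that a change in this part of the molecule can move the number. Within the data shown here, no measured step replaces the ring itself, so the direction remains open. No step beyond the scatter is therefore expected, and the range is kept wide on the lower side. The expected step is a 1.5-fold lower number from compound 2 to compound 4 (0.16 log units; within the scatter). For compound 4 the estimated value is 22000 nM, with an expected range from 7000 nM to 70000 nM.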

Compound 4, half-maximal cytotoxic concentration: 24000 nM
Compound 4: middle estimate off by 1.1-fold (0.04 log units), on the low side; low and high end bracket the measured number.
By their numbers in this assay, from the lowest: compound 3; then compounds 4 and 2 (each within the scatter of the next). At a limit, above all of these: compound 1.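

In this assay, cyclohexyl in place of phenyl on an aromatic carbon, between two ring nitrogen atoms, gives a 1.3-fold lower number from compound 2 to compound 4 (0.12 log units; within the scatter), so at this position a non-aromatic carbon ring takes the place of the aromatic one with no step beyond the scatter. The earlier compounds shown here offered only a substitution on the phenyl group, a 6.4-fold lower number from compound 2 to compound 3 (0.81 log units; beyond the scatter), and no replacement of the ring itself; this pair shows that, on this thiosemicarbazone-bearing core, the aromatic character of the ring is not needed to keep the number where it stands. Compound 2 and compound 4 both give true numbers, so this step is read from two measured values and is not limited by the top of the assay: the limit of > 100000 nM in this assay, at which 1 of the 4 values shown sits.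

The compounds shown leave open how far this tolerance extends, since a methyl group, a longer alkyl chain or a piperidine ring at this place would test whether a six-membered carbon ring is needed at all. Going by these compounds, it also remains open whether trifluoromethyl on the cyclohexyl ring would give a step like the one seen on the phenyl ring.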